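The source may hold more compounds than are shown below. What is called first, only, known or untested is meant among the compounds shown, and "the series" means these compounds.

Compound 1 `Cc1ccc(/C=C2\CN(Cc3cn(Cc4ccc(F)cc4)nn3)C/C(=C\c3ccc(C)cc3)C2=O)cc1` and compound 2 `Cc1ccc(/C=C2\CN(Cc3cn(Cc4cccc(Cl)c4)nn3)C/C(=C\c3ccc(C)cc3)C2=O)cc1` share one core and differ only at the outer end of the side chain. In a functional assay on 4T1 cells (Mus musculus) for cytotoxicity, read by MTT assay, with a stated time of 24 h (on this read-out higher numbers stand for weaker inhibition and lower numbers for stronger inhibition), compound 1 gives 57200 nM, while compound 2 gives 29300 nM. The change between them, (3-chlorophenyl in place of 4-fluorophenyl on a saturated chain carbon bound to an aromatic nitrogen), produced a 2.0-fold lower number from compound 1 to compound 2 (0.29 log units; within the scatter), a small step that could still be noise.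

Compound 3 `O=C1/C(=C/c2ccccc2F)CN(C(=S)SCc2cn(Cc3ccc(F)cc3)nn2)C/C1=C\c1ccccc1F` is built on another core; the difference between the two cores is not broken down here. In this assay compound 3 gives 9900 nM, the lowest of the three numbers. Compound 4 `O=C1/C(=C/c2ccccc2F)CN(C(=S)SCc2cn(Cc3cccc(Cl)c3)nn2)C/C1=C\c1ccccc1F` repeats the same change on this second core, (3-chlorophenyl in place of 4-fluorophenyl on a saturated chain carbon bound to an aromatic nitrogen), at a place described in the same words.

Because compound 1 to compound 2 gave a 2.0-fold lower number from compound 1 to compound 2 (0.29 log units; within the scatter), a similar step a 1.8-fold lower number from compound 3 to compound 4 (0.26 log units; within the scatter) is expected for compound 4. Compound 4 is estimated at 5500 nM, likely between 2000 nM and 15000 nM.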

Compound 4, half-maximal inhibitory concentration: > 100000 nM
Compound 4: only a limit was reported (the forecaster's own chance of this, stated with the estimate: 5%); middle value at least 18-fold (1.25 log units) away from the limit.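

On the second core, 3-chlorophenyl in place of 4-fluorophenyl gave an at least 10-fold higher number from compound 3 to compound 4 (1.00 log units; beyond the scatter). For compound 4, > 100000 nM is a limit of the assay and not a number, so the full size of this step is not known. The change therefore did not carry over from one core to the other, although a single pair on each core cannot show which feature of the cores is responsible: the same change on two cores in this assay, a 2.0-fold lower number (0.29 log units; within the scatter) from compound 1 to compound 2 and an at least 10-fold higher number (1.00 log units; beyond the scatter) from compound 3 to compound 4, at least 19-fold (1.29 log units) apart, beyond the scatter of two such steps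

Which part of the difference between the two cores goes with this split remains open. So does how a plain benzyl group or a methoxybenzyl group would behave on each core.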